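This account rests on a few compounds, and the source may have more. Where it says the series, first, only, none or still open, it means among the compounds named here.

Measured in a functional assay on MCF7 cells (Homo sapiens) for antiproliferative activity, read by MTT assay, with a stated time of 72 h; on this read-out higher numbers stand for weaker inhibition and lower numbers for stronger inhibition:
compound 1, `CCCSc1nc(N/N=C/c2ccc(N(C)C)cc2)c2nnn(Cc3ccccc3)c2n1`, 12200 nM
compound 2, `CCCSc1nc(N/N=C(\C)c2ccc(O)cc2)c2nnn(Cc3ccccc3)c2n1`, 21600 nM
compound 3, `CCCSc1nc(N/N=C(\C)c2ccc(Br)cc2)c2nnn(Cc3ccccc3)c2n1`, 13000 nM

Compound 3 stands second highest of the three numbers in this assay. Going by the values given here, its number and that of compound 1 lie within the scatter of each other, and so do its number and that of compound 2; the one single-point step in the set, a 1.7-fold lower number from compound 2 to compound 3 (0.22 log units; within the scatter), is within the scatter as well. The three measured compounds therefore form a narrow band with no ordering that can be trusted.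

Compound 4, `CCCSc1nc(N/N=C/c2ccccc2)c2nnn(Cc3ccccc3)c2n1`, is unmeasured. Relative to compound 3 the change is a group of 8 heavy atoms (7 carbon, 1 nitrogen; one six-membered aromatic ring of carbon only) in place of a group of 10 heavy atoms (8 carbon, 1 nitrogen, 1 bromine; one six-membered aromatic ring of carbon only), on a nitrogen on an aromatic ring. No measured step matches this change directly: the only step shown, a 1.7-fold lower number from compound 2 to compound 3 (0.22 log units; within the scatter), concerns an exchange on the aromatic carbon and was within the scatter, and compound 1, which differs from compound 4 in the group on that same nitrogen, sits in the same band as compound 3. Nothing in the data points to a shift beyond the scatter in either direction in this assay.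

Compound 4 is therefore expected to stay close to compound 3, with an estimated step of a 1.1-fold higher number from compound 3 to compound 4 (0.03 log units; within the scatter). The estimate for compound 4 in this assay is 14000 nM, with an expected range from 6000 nM to 35000 nM.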

Compound 4, half-maximal inhibitory concentration: > 64000 nM
Compound 4: a limit, no number; the forecaster's own chance of this, stated with the estimate: 15%; middle value at least 4.5-fold (0.66 log units) from the limit.
By their numbers in this assay, from the lowest: compounds 1, 3 and 2 (each within the scatter of the next). At a limit, above all of these: compound 4.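

In this assay compound 4 gives a limit and not a number: the limit of > 64000 nM in this assay, at which 1 of the 4 values shown sits. Going by these compounds alone, the cleanest reading is the single exchange of hydrogen in place of dimethylamino on an aromatic carbon, an at least 5.2-fold higher number from compound 1 to compound 4 (0.71 log units; beyond the scatter), while the exchanges of the whole group on the nitrogen on an aromatic ring give an at least 4.9-fold higher number from compound 3 to compound 4 (0.69 log units; beyond the scatter) and an at least 2.9-fold higher number from compound 2 to compound 4 (0.47 log units; beyond the scatter), and these two cannot separate the substituent on the aromatic carbon from the rest of that group. Compound 1, compound 3 and compound 2, each within the scatter of the next, had made this part of the molecule look tolerant of change, whereas compound 4, with hydrogen on that aromatic carbon, falls outside their band, so the group on the nitrogen is not indifferent to the change.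

Going by these compounds, how far compound 4 lies beyond the others stays open, since its reading is a limit. Also open, on these data alone, is whether a primary amine, a methoxy group or a carboxylic acid in place of the dimethylamino group would stay in the band of compound 1 or fall away as compound 4 does.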